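Swapping the Acetylthiophene Tail for a Carboxymethylphenyl Group

A few compounds are considered here, and "the series" means these few. Any claim that something is new, unique, unknown or untested is made for them only; others in the source may bear on it.

Of the compounds shown here, three built on one shared amide core have been tested in an ADME assay on Raji cells (Homo sapiens) for cytotoxicity, read by CellTiter-Glo and resazurin assay, with a stated time of 72 h; a lower number here means that less compound is needed, a higher number that more compound is needed for the effect. Compound 1, `COc1cc(OC)cc(-c2ccc(C(=O)N(Cc3cccc(OCCCCCC(=O)O)c3)C(C)C)cc2)c1`, reaches only the limit of the assay, giving > 26000 nM. Compound 2, `CC(C)N(Cc1cccc(OCCCCCC(=O)O)c1)C(=O)c1ccc(-c2c[nH]c3ccccc23)cc1`, likewise stops at the limit with > 26000 nM. The change from compound 1 to compound 2 is a step that the two limits leave unreadable from compound 1 to compound 2, with 1H-indol-3-yl in place of 3,5-dimethoxyphenyl on an aromatic carbon. Compound 3, `CCOC(=O)CCCCCOc1cccc(CN(C(=O)c2ccc(-c3ccc(C(C)=O)s3)cc2)C(C)C)c1`, also reaches only the limit, giving > 26000 nM. So compound 3 stands exactly where every other measured value stands: all three sit at the limit of > 26000 nM in this assay, at which 3 of the 3 values shown sit, and no readable step exists anywhere among them.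

Compound 4, `CCOC(=O)CCCCCOc1cccc(CN(C(=O)c2ccc(-c3cccc(CC(=O)O)c3)cc2)C(C)C)c1`, differs from compound 3 by 3-(carboxymethyl)phenyl in place of 5-acetylthiophen-2-yl on an aromatic carbon. Going by the values given here, no measured step touches either 3-(carboxymethyl)phenyl or 5-acetylthiophen-2-yl, and the single measured step is unreadable, so the expected step is a step that the limit leaves unreadable from compound 3 to compound 4, with compound 4 most likely again beyond the limit. Compound 4 is therefore estimated at 40000 nM, within a range from 15000 nM to 120000 nM.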

Compound 4, half-maximal effective concentration: > 26000 nM
Compound 4: a limit, no number (the forecaster's own chance of this, stated with the estimate: 80%); the middle value is on the limit's open side.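

Going by these compounds alone, the change from compound 3 to compound 4 gives no step that can be read, since both values are limits and not numbers: the limit of > 26000 nM in this assay, at which 4 of the 4 values shown sit.

The compounds shown leave open how much compound any of the four would need for the effect in this assay, and which change to the shared core would give a readable number.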